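From Cyclohexyl to Benzyl on a Shared Core

This account rests on a few compounds, and the source may have more. Where it says the series, first, only, none or still open, it means among the compounds named here.

Compound 1 `CNc1nc(N)n2nc(-c3ccco3)nc2n1` gives in a functional assay on CHO cells for antagonist activity at adenosine receptor A2b (Homo sapiens) (a higher number here means a weaker inhibitor, a lower number a stronger inhibitor), only a limit of the assay, > 30000 nM.
Compound 2 `CC(C)Nc1nc(N)n2nc(-c3ccco3)nc2n1` gives in this assay only a limit, > 30000 nM.
Compound 3 `c1coc(-c2nc3nc(NC4CCCCC4)nc(NC4CCCCC4)n3n2)c1` gives in this assay only a limit, > 30000 nM.

In this assay, for the measured compounds named here, no measured compound yields a number; all three reach only the limit: the limit of > 30000 nM in this assay, at which 3 of the 3 values shown sit. Compound 3 therefore stands at that limit, with no number of its own, and the two further values shown are limits as well. Going by the values given here, the one measured step between compounds that differ in a single place, a step that the two limits leave unreadable from compound 1 to compound 2, runs from one limit to another, so its size cannot be read.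

Compound 4 `c1ccc(CNc2nc(NC3CCCCC3)n3nc(-c4ccco4)nc3n2)cc1` differs from compound 3 in one place: benzyl in place of cyclohexyl on a nitrogen on an aromatic ring. Among the compounds with values here, no measured step involves a benzyl group, so nothing measured bears directly on this change, and the single step between neighbours gives no readable size. The three values together show only that none of them has cleared the limit. The expectation for compound 4 is accordingly that it most likely sits near the limit too, with a wide range to allow for the aromatic ring that enters. The step from compound 3 to compound 4 is estimated as a number no higher from compound 3 to compound 4 (the limit leaves the size open). Compound 4 is estimated at 30000 nM, expected between 4000 nM and 100000 nM.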

Compound 4, half-maximal inhibitory concentration: > 30000 nM
Compound 4: only a limit was reported; the forecaster's own chance of this, stated with the estimate: 65%; the middle value sits exactly at the limit.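

Benzyl in place of cyclohexyl gives no readable step between compound 3 and compound 4, because both give only a limit of the assay rather than a number: the limit of > 30000 nM in this assay, at which 4 of the 4 values shown sit.

Left open is how far each of these compounds lies from that limit, and so whether benzyl or cyclohexyl gives the stronger inhibitor on the shared core.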